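Pyridyl Sulfone in Place of a Hydroxyphenyl Sulfone

The compounds below may be only part of what the source reports. "The series", "measured", "known", "first", "only" and "open" are said of these compounds alone.

The measured compounds and their values:

Compound 1, `CC(O)(C(=O)Nc1ccc(S(=O)(=O)c2ccccc2O)cc1)C(F)(F)F`: 3090 nM
Compound 2, `CC(O)(C(=O)Nc1ccc(C(=O)c2ccccc2)c(F)c1)C(F)(F)F`: 2700 nM
Compound 3, `CC(O)(C(=O)Nc1ccc(C(=O)c2ccccc2F)cc1)C(F)(F)F`: 2300 nM

All three share the same core, and all three were tested in a functional assay (Cavia porcellus) with sulfonylurea receptors; K-ATP channels (Homo sapiens) as the target; on this read-out higher numbers stand for weaker inhibition and lower numbers for stronger inhibition. Compound 1 gives 3090 nM, the highest of the three numbers, yet the numbers for compound 2 and compound 3 lie within the usual scatter of it, so the three cannot be ranked against one another on this evidence.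

Compound 4, `CC(O)(C(=O)Nc1ccc(S(=O)(=O)c2ccccn2)cc1)C(F)(F)F`, has not yet been measured. It differs from compound 1 in one place: pyridin-2-yl in place of 2-hydroxyphenyl on a sulfonyl sulfur. For the measured compounds named here, no pair of measured compounds differs in a single place, so there is no measured step in this assay to lean on. What the data do show is that three compounds differing in several places all land close together, which argues against a large shift for a single change of this kind. The expectation is therefore a step of modest size, in no firm direction, and quite possibly one that stays within the scatter.

Compound 4 is expected to give about 3000 nM in this assay, with a range from 1000 nM to 9000 nM. The estimated step of a 1.0-fold lower number from compound 1 to compound 4 (0.01 log units; within the scatter) is accordingly small.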

Compound 4, half-maximal inhibitory concentration: 600 nM
Estimate against measurement, compound 4: 5.0-fold (0.70 log units) above; the measured number lies below the stated range.
By their numbers in this assay, from the lowest: compound 4; then compounds 3, 2 and 1 (each within the scatter of the next).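

Putting pyridin-2-yl in place of 2-hydroxyphenyl on the sulfonyl sulfur gives a 5.2-fold lower number from compound 1 to compound 4 (0.71 log units; beyond the scatter) in this assay. For the compounds shown here, this is the first change in the set that can be read in a single place, and it shows that the aromatic group on the sulfonyl sulfur can move the number beyond the scatter, something the close values of the earlier compounds could not reveal. The change takes away a hydrogen-bond donor and brings a nitrogen into the ring, but nothing measured here tells which of these matters or explains the lower number.

The two features of the change therefore remain tangled: a plain phenyl on the sulfonyl sulfur would have neither the hydroxyl nor the ring nitrogen, while a 2-methoxyphenyl group would keep an oxygen in the group without its hydrogen-bond donor. As far as these compounds go, it also remains open whether pyridin-2-yl would have a similar effect in the carbonyl compounds, compound 2 and compound 3, or whether the lower number holds only on a sulfonyl sulfur.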